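Alkyne in the side chain of the diaminopyrimidine series

The compounds below may be only part of what the source reports. "The series", "measured", "known", "first", "only" and "open" are said of these compounds alone.

Measured compounds: compound 1 `CCCCNc1nc(N)nc(C)c1CCCC`, 780 nM; compound 2 `CCCCNc1nc(N)nc(C)c1CCCN(C)C`, 126 nM; compound 3 `CCCCCc1c(C)nc(N)nc1NCCCC`, 1220 nM.

All three numbers come from an assay on HEK293 cells for agonist activity at Toll-like receptor 8 (Homo sapiens), read by spectrophotometry; a lower number here means that less compound is needed, a higher number that more compound is needed for the effect. Compound 3 has the highest number of the three; the gap to compound 1, a 1.6-fold higher number from compound 1 to compound 3 (0.19 log units; within the scatter), is within the scatter, while the gap to compound 2, a 9.7-fold higher number from compound 2 to compound 3 (0.99 log units; beyond the scatter), is beyond it. Within the data shown here, the only step beyond the scatter, a 6.2-fold lower number from compound 1 to compound 2 (0.79 log units; beyond the scatter), concerns a dimethylamino group and has no counterpart here.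

Compound 4 `CCCC#Cc1c(C)nc(N)nc1NCCCC` differs from compound 3 by pent-1-yn-1-yl in place of pentyl on an aromatic carbon. Among the measured compounds shown here, no measured step involves a triple bond in this chain, so no step beyond the scatter is expected in this assay: a 1.0-fold lower number from compound 3 to compound 4 (0.01 log units; within the scatter). Compound 4 is estimated at 1200 nM, range 400 nM to 3600 nM.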

Compound 4, half-maximal effective concentration: 5000 nM
For compound 4 the middle estimate is 4.2-fold (0.62 log units) below the measured one; the measured number lies above the stated range.
By their numbers in this assay, from the lowest: compound 2; then compounds 1 and 3 (each within the scatter of the next); then compound 4.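

On the aromatic carbon ortho to the butylamino group, the chain's bond type matters in this assay: with 5 heavy atoms in both chains, pent-1-yn-1-yl in place of pentyl gives a 4.1-fold higher number from compound 3 to compound 4 (0.61 log units; beyond the scatter). Against the butyl chain the step is a 6.4-fold higher number from compound 1 to compound 4 (0.81 log units; beyond the scatter), and against 3-(dimethylamino)propyl it widens to a 40-fold higher number from compound 2 to compound 4 (1.60 log units; beyond the scatter). Nothing available accounts for the effect of the triple bond.

Open, going by these compounds, is whether a double bond in the same chain behaves like the pentyl or the pent-1-yn-1-yl chain. Also open, on these data alone, is whether a dimethylamino group at the end of the alkyne chain lowers the number as it does on the saturated chain.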